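Swapping the aryl group on the pyridazinone nitrogen

The compounds below may be only part of what the source reports. "The series", "measured", "known", "first", "only" and "open" are said of these compounds alone.

Of the compounds shown here, three have been measured so far in a functional assay on MCF7 cells (Homo sapiens) for cytotoxicity, read by MTT assay, with a stated time of 72 h; on this read-out higher numbers stand for weaker inhibition and lower numbers for stronger inhibition. Compound 1 `CNC(=O)c1cc(Oc2ccc(NC(=O)c3nn(-c4ccccc4OC(F)(F)F)c(=O)cc3C)cc2F)ccn1` gives only a limit in this assay, > 40000 nM. Compound 2 `Cc1cc(=O)n(-c2ccc(F)c(F)c2)nc1C(=O)Nc1ccc(Oc2ncnc3ccsc23)cc1` gives 5550 nM in this assay, while compound 3 `Cc1cc(=O)n(-c2ccccc2OC(F)(F)F)nc1C(=O)Nc1ccc(Oc2ncnc3ccsc23)c(F)c1` gives 11500 nM, which is the higher of the two real numbers; the gap between these two values lies beyond the scatter. Among the measured compounds shown here, the only step measured in one place is an at least 3.4-fold lower number from compound 1 to compound 3 (0.54 log units; beyond the scatter), and it touches the ether-linked part of the molecule, not the part that changes next, so it says little about the step ahead.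

Compound 4 `Cc1cc(=O)n(-c2ccc(F)c(F)c2)nc1C(=O)Nc1ccc(Oc2ncnc3ccsc23)c(F)c1` differs from compound 3 by 3,4-difluorophenyl in place of 2-(trifluoromethoxy)phenyl on an aromatic nitrogen. Compound 2 already carries the same 3,4-difluorophenyl group and gives 5550 nM in this assay. A step toward a lower number, of roughly that size, is therefore expected: a 1.8-fold lower number from compound 3 to compound 4 (0.25 log units; within the scatter). Compound 4 is expected to give about 6500 nM in this assay, within a range from 2500 nM to 16000 nM.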

Compound 4, half-maximal inhibitory concentration: 6900 nM
Estimate against measurement, compound 4: 1.1-fold (0.03 log units) below; low and high end bracket the measured number.
By their numbers in this assay, from the lowest: compounds 2, 4 and 3 (each within the scatter of the next, the first and the last beyond it). At a limit, above all of these: compound 1.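

In this assay, putting 3,4-difluorophenyl in place of 2-(trifluoromethoxy)phenyl on the aromatic nitrogen gives a 1.7-fold lower number from compound 3 to compound 4 (0.22 log units; within the scatter), so these two aryl groups cannot be told apart at this position. The fluoro on the aromatic carbon, now seen as a single change, gives a 1.2-fold higher number from compound 2 to compound 4 (0.09 log units; within the scatter), so that pair cannot be told apart either. Nothing shown here explains why these groups read alike.

From the compounds shown here alone, both groups at this position are phenyl rings carrying fluorine, so it remains open how the read-out would respond to a plain phenyl, a cyclohexyl ring or a methyl on that nitrogen. A phenyl ring carrying an amine or a carboxylic acid is also untested among the compounds shown, so the limits of what this position accepts are still unknown.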